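A few compounds are considered here, and "the series" means these few. Any claim that something is new, unique, unknown or untested is made for them only; others in the source may bear on it.

Of the compounds shown here, three sharing one core have been measured in an in vitro functional assay on cells for agonist activity at Bombesin receptor subtype-3 (Homo sapiens), read by luminescence and calcium flux; a lower number here means that less compound is needed, a higher number that more compound is needed for the effect. Compound 1 `O=C(O)c1ccccc1-c1ccc(CCc2ncc(CC3CCOCC3)[nH]2)cc1` gives 338 nM. Compound 2 `COc1cccc(Cc2cnc(CCc3ccc(-c4ccccc4C(=O)O)cc3)[nH]2)c1` gives 4120 nM, and compound 3 `CC(C)(C)c1cnc(CCc2ccc(-c3ccccc3C(=O)O)cc2)[nH]1` gives 4330 nM. Compound 2 therefore stands second highest of the three numbers, close to compound 3 and far from compound 1.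

The step from compound 2 to compound 4 `CCC(C)(CC)Cc1cnc(CCc2ccc(-c3ccccc3C(=O)O)cc2)[nH]1` is 1-ethyl-1-methylpropyl in place of 3-methoxyphenyl on a saturated chain carbon bound to an aromatic carbon. The measured steps show a 12-fold higher number from compound 1 to compound 2 (1.09 log units; beyond the scatter) and a 13-fold higher number from compound 1 to compound 3 (1.11 log units; beyond the scatter), while between the two weaker compounds there is only a 1.1-fold higher number from compound 2 to compound 3 (0.02 log units; within the scatter). Compound 3 carries a tert-butyl, a branched chain like the 1-ethyl-1-methylpropyl entering in compound 4, and compound 3 sits within the scatter of compound 2. Compound 4 is therefore expected to stay near compounds 2 and 3, with a 1.0-fold lower number from compound 2 to compound 4 (0.01 log units; within the scatter) in this assay as the expected step. The estimate for compound 4 is 4000 nM, with a range from 1500 nM to 11000 nM.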

Compound 4, half-maximal effective concentration: 76 nM
Estimate against measurement, compound 4: 53-fold (1.72 log units) above; measured number outside the range, below it.
By their numbers in this assay, from the lowest: compound 4; then compound 1; then compounds 2 and 3 (each within the scatter of the next).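

In this assay, among these compounds, the earlier compounds showed changes at this place only raising the number, whereas 1-ethyl-1-methylpropyl in place of 3-methoxyphenyl lowers it, with a 54-fold lower number from compound 2 to compound 4 (1.73 log units; beyond the scatter) on a saturated chain carbon bound to an aromatic carbon. A branched all-carbon group as such does not guarantee a low number, for 2-ethyl-2-methylbutyl in place of tert-butyl gives a 57-fold lower number from compound 3 to compound 4 (1.76 log units; beyond the scatter) and so separates two branched groups widely. The new group also improves on the oxan-4-yl of the previously lowest compound, with a 4.4-fold lower number from compound 1 to compound 4 (0.65 log units; beyond the scatter) as a modest but real step, leaving compound 4 with the lowest number of the four.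

No evidence on the cause of these steps is available. From the compounds shown here alone, it remains open whether a cyclohexyl group or an amine in place of 1-ethyl-1-methylpropyl would keep the number this low.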